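Compound 3: back to a furan, now brominated

This account rests on a few compounds, and the source may have more. Where it says the series, first, only, none or still open, it means among the compounds named here.

Measured in a functional assay on cells (Neutrophil, Rattus norvegicus) for inhibition; on this read-out lower numbers stand for stronger inhibition and higher numbers for weaker inhibition:
- Compound 1 `COc1ccc(OC)c(C(=O)/C=C/c2ccco2)c1`: 3000 nM
- Compound 2 `COc1ccc(OC)c(C(=O)/C=C/c2ccc(C)s2)c1`: > 30000 nM (a limit, not a number)

Compound 2 is known only as a limit: it stands at the limit of > 30000 nM in this assay, at which 1 of the 2 values shown sits. The next compound, compound 3 `COc1ccc(OC)c(C(=O)/C=C/c2occc2Br)c1`, differs from it as follows: 3-bromofuran-2-yl in place of 5-methylthiophen-2-yl on a double-bonded chain carbon bound to a double-bonded chain carbon. Within the data shown here, only one measured step bears on this change: an at least 10-fold higher number from compound 1 to compound 2 (1.00 log units; beyond the scatter). That step replaced furan-2-yl with 5-methylthiophen-2-yl, and compound 3 returns to a furan, now as 3-bromofuran-2-yl. Among the measured compounds shown here, compound 1 is the only measured compound with a furan, and it gives 3000 nM. For the measured compounds named here, no measured compound carries a bromine, so how far compound 3 will sit from compound 1 remains open. A single step also cannot show a trend. With compound 1 at 3000 nM as the nearest reference, a lower number than for compound 2 is expected in this assay. Compound 3 could also reach the same limit as compound 2. The expected size is an at least 5.0-fold lower number from compound 2 to compound 3 (0.69 log units; beyond the scatter). For compound 3 the estimate is 6000 nM, with an expected range of 1500 nM to 25000 nM.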

Compound 3, half-maximal inhibitory concentration: 19700 nM
Beside the measured number, compound 3's estimate is 3.3-fold (0.52 log units) below it; the measured number falls inside the stated range.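

Among these compounds, compound 3 gives the first reading on a substituent on the furan itself in this assay: bromo in place of hydrogen on an aromatic carbon gives a 6.6-fold higher number from compound 1 to compound 3 (0.82 log units; beyond the scatter) and so the furan alone does not secure the number of compound 1. The other step, for 3-bromofuran-2-yl in place of 5-methylthiophen-2-yl, is an at least 1.5-fold lower number from compound 2 to compound 3 (0.18 log units; that floor lies within the scatter) and so does not establish a firm gain from this exchange. Compound 2 remains a limit and not a number, which leaves the true size of that step unknown: the limit of > 30000 nM in this assay, at which 1 of the 3 values shown sits.

Still open, on these data alone, is whether the higher number of compound 3 belongs to bromo in particular, or whether a chloro or an amino group on the same aromatic carbon would stay closer to compound 1 at 3000 nM in this assay. Also open, as far as these compounds go, is how much of the step to compound 2 belongs to the sulfur-containing ring and how much to its methyl group, a question that a plain thiophen-2-yl group would separate.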